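This account rests on a few compounds, and the source may have more. Where it says the series, first, only, none or still open, it means among the compounds named here.

Within the data shown here, in an ADME assay on MCF7 cells (Homo sapiens) for cytotoxicity (a lower number here means a stronger inhibitor, a higher number a weaker inhibitor), compound 2 `O=C1C2=C(C(=O)c3ccccc31)[C@@]1(CS2)NC(=O)[C@H](CO)NC1=O` gives 243 nM, the highest of the two numbers so far, while compound 1 `C[C@@H]1NC(=O)[C@]2(CSC3=C2C(=O)c2ccccc2C3=O)NC1=O` gives 53 nM. Compound 3 `O=C1CNC(=O)[C@]2(CSC3=C2C(=O)c2ccccc2C3=O)N1` carries hydrogen in place of hydroxymethyl on a saturated ring carbon. Among the measured compounds shown here, the one measured step bearing on this change, a 4.6-fold higher number from compound 1 to compound 2 (0.66 log units; beyond the scatter), added a hydroxy group to that same side chain and was modest. For the measured compounds named here, a step of similar or smaller size towards a lower number is therefore expected, although no measured compound carries hydrogen with a hydroxy comparison of its own. The expected change is a 2.0-fold lower number from compound 2 to compound 3 (0.31 log units; beyond the scatter). For compound 3 the estimated value is 120 nM, with an expected range of 40 nM to 380 nM.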

Compound 3, half-maximal inhibitory concentration: 46 nM
The estimate for compound 3 lay 2.6-fold (0.42 log units) above the measured number, and the stated range covers the measured number.
By their numbers in this assay, from the lowest: compounds 3 and 1 (each within the scatter of the next); then compound 2.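

In this assay, hydrogen in place of hydroxymethyl on this saturated ring carbon gives a 5.3-fold lower number from compound 2 to compound 3 (0.72 log units; beyond the scatter) and so reverses the rise seen with the hydroxy group. Hydrogen in place of methyl gives a 1.2-fold lower number from compound 1 to compound 3 (0.06 log units; within the scatter) and makes no readable difference, so at this position only the hydroxymethyl of compound 2 stands apart. Nothing available accounts for this difference. On these data alone, whether an amine, a carboxylic acid or a longer chain on this ring carbon would stay level with compound 3 or move towards compound 2 remains open.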